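The source may hold more compounds than are shown below. What is called first, only, known or untested is meant among the compounds shown, and "the series" means these compounds.

Three compounds have been measured in a functional assay on HT-29 cells (Homo sapiens) for antiproliferative activity, read by sulforhodamine B assay, with a stated time of 48 h; a higher number here means a weaker inhibitor, a lower number a stronger inhibitor:
compound 1 `CC(C)C(=O)Nc1ccc(S(=O)(=O)Oc2ccccc2I)cc1` gives 13000 nM;
compound 2 `CCCNC(=O)Nc1ccc(S(=O)(=O)Oc2ccccc2I)cc1` gives 6800 nM;
compound 3 `O=C(Nc1ccc(S(=O)(=O)Oc2ccccc2I)cc1)NC1CC1` gives 14000 nM.

On these numbers compound 3 has the highest value of the three, though its gap to compound 1 is within the scatter (a 1.1-fold higher number from compound 1 to compound 3 (0.03 log units; within the scatter)), while the step of a 2.1-fold higher number from compound 2 to compound 3 (0.31 log units; beyond the scatter) lies beyond it. Compound 4 `O=C(NCC1CCCC1)Nc1ccc(S(=O)(=O)Oc2ccccc2I)cc1` differs from compound 3 in one place: cyclopentylmethyl in place of cyclopropyl on an amide-type nitrogen. For the measured compounds named here, the one measured step that bears on this position is a 2.1-fold higher number from compound 2 to compound 3 (0.31 log units; beyond the scatter), a modest change at the amide-type nitrogen; read in the other direction it means a lower number for propyl than for cyclopropyl. The step of a 1.9-fold lower number from compound 1 to compound 2 (0.28 log units; within the scatter) touches the same region but stays within the scatter. Since the incoming cyclopentylmethyl is larger than cyclopropyl and, like propyl, is not a three-membered ring, a modestly lower number than in compound 3 is expected for compound 4 in this assay, about the size of a 1.8-fold lower number from compound 3 to compound 4 (0.24 log units; within the scatter). Compound 4 is therefore estimated at 8000 nM, with a range from 3000 nM to 25000 nM.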

Compound 4, half-maximal inhibitory concentration: 7600 nM
Estimate against measurement, compound 4: 1.1-fold (0.02 log units) above; measured number inside the range.
By their numbers in this assay, from the lowest: compounds 2, 4, 1 and 3 (each within the scatter of the next, the first and the last beyond it).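

In this assay the change from cyclopropyl to cyclopentylmethyl on the amide-type nitrogen gives a 1.8-fold lower number from compound 3 to compound 4 (0.27 log units; within the scatter) and shows that a five-membered ring carried on this nitrogen stands level with the three-membered one. The same compound reads as a 1.1-fold higher number from compound 2 to compound 4 (0.05 log units; within the scatter) against the propyl compound and as a 1.7-fold lower number from compound 1 to compound 4 (0.23 log units; within the scatter) against the isopropyl compound, so compound 4 cannot be told apart from any of the three. It thus bridges compound 2 and compound 3, whose own gap lies just beyond the scatter, and that gap alone marks no clear divide between ring and open chain at this position.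

As far as these compounds go, whether a group carrying an amine, a hydroxyl or a carboxylic acid, or a phenyl ring, on this nitrogen would move the number clear of the scatter remains open. No measurement here gives a reason for any of these numbers.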